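Benzyl fluorination within the piperidine amide series

The source may hold more compounds than are shown below. What is called first, only, known or untested is meant among the compounds shown, and "the series" means these compounds.

Three compounds have numbers in a functional assay on a cell-free system (Platelet, plasma, Homo sapiens), with stated times of 4 min and 5.5 min, tested at 0.5 uM; on this read-out higher numbers stand for a weaker effect at the one concentration tested and lower numbers for a stronger effect. Compound 1 `O=C(c1ccc[n+](Cc2ccccc2F)c1)N1CCN(c2ccccc2Cl)CC1` gives 89%. Compound 2 `COc1cc(C(=O)[n+]2cccc(C(=O)N3CCN(c4ccccc4Cl)CC3)c2)cc(OC)c1OC` gives 20%. Compound 3 `O=C(C1CCCN(Cc2ccccc2)C1)N1CCN(c2ccccc2Cl)CC1` gives 26%, which stands second highest of the three; its gap to compound 2 lies within the scatter, so no order between those two can be read, while its gap to compound 1 is far beyond the scatter, compound 1 showing the markedly weaker effect at the concentration tested.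

Compound 4 `O=C(C1CCCN(Cc2ccc(F)cc2)C1)N1CCN(c2ccccc2Cl)CC1` differs from compound 3 in one place: fluoro in place of hydrogen on an aromatic carbon, benzyl to 4-fluorobenzyl. Among the measured compounds shown here, no measured pair in the set shows the effect of such a change, so the step has to be judged from the change itself, which adds a single heavy atom and no charge, donor or acceptor. The expected step from compound 3 to compound 4 in this assay is a number 2 percentage points higher from compound 3 to compound 4 (within the scatter), that is, none beyond the scatter. Compound 4 is therefore estimated at 28%, with a range of 12% to 50%.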

Compound 4, a percentage reported as activity, at one concentration (the size of the read-out at that concentration, not a potency): 67%
Compound 4: middle estimate off by 39 percentage points, on the low side; the whole stated range lies below it.
By their numbers in this assay, from the lowest: compounds 2 and 3 (each within the scatter of the next); then compound 4; then compound 1.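

In this assay, benzyl to 4-fluorobenzyl gives a number 41 percentage points higher from compound 3 to compound 4 (beyond the scatter), so the effect at the one concentration tested weakens markedly. Among the compounds shown here, this is the first step between compounds that differ in one place, and it shows that this aromatic carbon, para to a large group, is not indifferent to substitution: one fluoro, with no charge, donor or acceptor, is enough for a large step. Nothing available bears on what lies behind this step.

On these data alone, whether the step belongs to fluoro itself or would come with any group on this carbon stays open; chloro, methyl or methoxy in the same place would separate the two. Also open, as far as these compounds go, is whether fluoro on the other carbons of this ring gives a step of similar size.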